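Series notes: phenoxy to benzyl on the amine chain

The compounds below may be only part of what the source reports. "The series", "measured", "known", "first", "only" and "open" are said of these compounds alone.

Within the data shown here, compound 1 `O=C(NO)c1ccc(-c2ccc(CNCCOc3ccccc3)cn2)s1` gives 110 nM in a functional assay on MCF7 cells (Homo sapiens) for inhibition (on this read-out higher numbers stand for weaker inhibition and lower numbers for stronger inhibition), the lowest number among the three measured so far. Compound 3 `O=C(NO)c1ccc(-c2ccc(CNCc3ccc(-c4ccccc4)cc3)cn2)s1` gives 150 nM in this assay, within the scatter of compound 1. Compound 2 `O=C(NO)c1ccc(-c2ccc(CNc3ccccc3)cn2)s1` gives 370 nM in this assay, which lies beyond the scatter from compound 1. Compound 4 `O=C(NO)c1ccc(-c2ccc(CNCCCc3ccccc3)cn2)s1` has not yet been measured. Its difference from compound 1: benzyl in place of phenoxy on a saturated chain carbon, two bonds along the chain from an amine nitrogen. Among the measured compounds shown here, no single-point step between measured compounds is available, so the step is judged from the change alone; both groups are of equal size and each holds one six-membered aromatic ring of carbon only, and the step from compound 1 to compound 4 in this assay is expected to be a 1.4-fold higher number from compound 1 to compound 4 (0.13 log units; within the scatter), not beyond the scatter. Compound 4 is therefore estimated at 150 nM, with a range of 60 nM to 400 nM.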

Compound 4, half-maximal inhibitory concentration: 120 nM
Compound 4: the middle estimate sits 1.3-fold (0.10 log units) above what was measured; measured number inside the range.
By their numbers in this assay, from the lowest: compounds 1, 4 and 3 (each within the scatter of the next); then compound 2.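

Among these compounds, a step of a 1.1-fold higher number from compound 1 to compound 4 (0.04 log units; within the scatter) in this assay gives the first direct reading at this position: with benzyl in place of phenoxy on a saturated chain carbon, two bonds along the chain from an amine nitrogen, the oxygen and its hydrogen-bond acceptor leave without a change beyond the scatter. No supporting measurement bears on this result. Still open, as far as these compounds go, is whether this holds for a longer chain, or for a terminal amine or carboxylic acid at the same place.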